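Benzanilide terminus: methoxyphenyl to aminophenyl

The source may hold more compounds than are shown below. What is called first, only, known or untested is meant among the compounds shown, and "the series" means these compounds.

Compound 3 `COc1ccc(C(=O)Nc2cccc(NC(=O)COc3ccc4c(=O)ccoc4c3)c2)cc1` sets the mark in an assay on isolated protein for inhibition of Rho-associated protein kinase 2 (Homo sapiens), read by scintillation counting, radiometric assay and 33P incorporation, with a stated time of 40 min, in the presence of a further agent that is not named here; a lower number here means a stronger inhibitor, a higher number a weaker inhibitor: compound 3 gives 7 nM, the lowest of the two numbers in hand. Compound 2 `Cc1coc2cc(OCC(=O)Nc3cccc(NC(=O)c4ccc(N(C)C)cc4)c3)ccc2c1=O` gives 2150 nM in this assay, a separation from compound 3 that lies well beyond the scatter of the method. Compound 1 `CN(C)c1ccc(C(=O)Nc2cccc(NC(=O)COc3ccc4occc(=O)c4c3)c2)cc1` gives > 10000 nM in this assay, and this is a limit of the assay rather than a number; the limit of > 10000 nM in this assay, at which 1 of the 3 values shown sits, applies to compound 1 alone.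

Compound 4 `Nc1cccc(C(=O)Nc2cccc(NC(=O)COc3ccc4c(=O)ccoc4c3)c2)c1` is the next member and has not yet been measured. (3-aminophenyl in place of 4-methoxyphenyl on a carbonyl carbon). Within the data shown here, no measured pair in the set carries a change of this kind, so no step size can be read off for it. The expectation is a small step toward weaker inhibition in this assay, of a size that may or may not exceed the scatter. Compound 4 is therefore expected to give about 30 nM in this assay, with a likely range from 6 nM to 200 nM. The expected step is a 4.3-fold higher number from compound 3 to compound 4 (0.63 log units; beyond the scatter).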

Compound 4, half-maximal inhibitory concentration: 58 nM
The estimate for compound 4 lay 1.9-fold (0.29 log units) below the measured number; low and high end bracket the measured number.
By their numbers in this assay, from the lowest: compound 3; then compound 4; then compound 2. At a limit, above all of these: compound 1.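

In this assay, the first step readable at this terminus (an 8.3-fold higher number from compound 3 to compound 4 (0.92 log units; beyond the scatter)) shows that the position accepts 3-aminophenyl in place of 4-methoxyphenyl with a modest loss, and that the entering group's hydrogen-bond donor does not match the number given by compound 3. The change alters both the group and where it sits on the ring, so the step belongs to the whole swap and to neither part alone. No measured property in hand bears on this step.

The compounds shown do not separate those two parts, and they leave open whether a hydroxyl or a carboxylic acid in place of the amine would be tolerated here. Steps to compound 1 and compound 2 cannot be read, as each differs from compound 3 in more than one place.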